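Selenium series on leukemia cells: benzyl to methyl step

The source may report more compounds than this note shows. Statements on the series, on what has been measured and on what is new or still open speak of the compounds shown alone.

Working notes on the series. In a functional assay on K562 cells (Homo sapiens) for cytotoxicity, read by MTT assay, with a stated time of 72 h (on this read-out lower numbers stand for higher toxicity in this test and higher numbers for lower toxicity in this test), compound 1 `CS/C(=N\C(=O)c1csc([N+](=O)[O-])c1)NC(=O)c1csc([N+](=O)[O-])c1` reaches only the limit of the test and gives > 100000 nM, the limit (the limit of > 100000 nM in this assay, at which 1 of the 3 values shown sits). Compound 2 `CS/C(=N\C(=O)c1cc2ccccc2s1)NC(=O)c1cc2ccccc2s1` gives 98600 nM in this assay. Compound 3 `O=C(/N=C(/NC(=O)c1csc([N+](=O)[O-])c1)[Se]Cc1ccccc1)c1csc([N+](=O)[O-])c1` gives 88200 nM in this assay; the numbers of compound 3 and compound 2 sit within the scatter of each other, so compound 3 cannot be set apart from compound 2. Compound 1 offers no number for such a comparison, so compound 3 cannot be set apart from compound 1 either.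

Within the data shown here, the single measured step, an at least 1.1-fold lower number from compound 1 to compound 3 (0.05 log units; that floor lies within the scatter), alters the group on the carbon with a double bond to nitrogen and reads only as a floor that lies within the scatter.

Compound 4 `C[Se]/C(=N\C(=O)c1csc([N+](=O)[O-])c1)NC(=O)c1csc([N+](=O)[O-])c1` differs from compound 3 by hydrogen in place of phenyl on a saturated chain carbon bound to a selenium atom, or benzyl to methyl. The measured step overlaps this change only in part, and its floor lies within the scatter, so no step beyond the scatter is expected. For compound 4 the expected step is a 1.1-fold higher number from compound 3 to compound 4 (0.05 log units; within the scatter). Compound 4 is estimated at 100000 nM, ranging from 55000 nM to 180000 nM, with a fair chance that the assay again reports only a limit.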

Compound 4, concentration lethal to 50% of the cells: > 100000 nM
Compound 4: a limit, no number (the forecaster's own chance of this, stated with the estimate: 40%); the middle value sits exactly at the limit.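

Benzyl to methyl on selenium gives an at least 1.1-fold higher number from compound 3 to compound 4 (0.05 log units; that floor lies within the scatter) in this assay, a floor only, so the phenyl on this saturated chain carbon is not shown to matter, and the true size of its removal stays unknown. Compound 1 and compound 4 are both limits, so the step of selenium in place of sulfur with the methyl kept cannot be read. The methyl on selenium thus stands with the methyl on sulfur at the limit of the test: the limit of > 100000 nM in this assay, at which 2 of the 4 values shown sit.

On these data alone, how far compound 4 lies past its limit stays open, and with it any real effect of the phenyl. Also open, as far as these compounds go, is whether a longer chain such as ethyl, or a carboxylic acid on the chain, at this selenium would give a number within the range of the test.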